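Amide cap changes on the piperidine series

A few compounds are considered here, and "the series" means these few. Any claim that something is new, unique, unknown or untested is made for them only; others in the source may bear on it.

Three compounds share one core and differ only in the group on the amine nitrogen in the ring. In an assay on membranes from Cortex for displacement of a labelled ligand from Sigma non-opioid intracellular receptor 1 (Cavia porcellus), read by scintillation counting, with a stated time of 120 min (on this read-out higher numbers stand for weaker inhibition and lower numbers for stronger inhibition), compound 1 `OC(Cc1ccccc1)CN1CCC(NCCSC(c2ccc(F)cc2)c2ccc(F)cc2)CC1` gives 309 nM, compound 2 `O=C(c1ccc(F)cc1)N1CCC(NCCSC(c2ccc(F)cc2)c2ccc(F)cc2)CC1` gives 32.1 nM, and compound 3 `O=C(c1cc2ccccc2o1)N1CCC(NCCSC(c2ccc(F)cc2)c2ccc(F)cc2)CC1` gives 304 nM. Compound 3 stands second highest of the three numbers: it is within the scatter of compound 1 and, as the step of a 9.5-fold higher number from compound 2 to compound 3 (0.98 log units; beyond the scatter) shows, well above compound 2. Compound 4 `CC(C)(C)C(=O)N1CCC(NCCSC(c2ccc(F)cc2)c2ccc(F)cc2)CC1` carries the change (tert-butyl in place of 1-benzofuran-2-yl on a carbonyl carbon). Going by the values given here, the only measured step on the same carbonyl carbon is a 9.5-fold higher number from compound 2 to compound 3 (0.98 log units; beyond the scatter), which shows that swapping the group on that carbon can move this assay beyond the scatter; the steps of a 9.6-fold lower number from compound 1 to compound 2 (0.98 log units; beyond the scatter) and a 1.0-fold lower number from compound 1 to compound 3 (0.01 log units; within the scatter) show the same spread across the whole cap. Among the compounds with values here, no measured compound carries a cap without a ring, so the direction is open. For compound 4 a number near the middle of the spread is expected, 150 nM, with a wide range from 30 nM to 800 nM. The corresponding step is expected to read a 2.0-fold lower number from compound 3 to compound 4 (0.31 log units; beyond the scatter).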

Compound 4, inhibition constant: 163 nM
Beside the measured number, compound 4's estimate is 1.1-fold (0.04 log units) below it, within the range that was stated.
By their numbers in this assay, from the lowest: compound 2; then compounds 4, 3 and 1 (each within the scatter of the next).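

A cap with no ring on the carbonyl carbon sits in the same band as the 1-benzofuran-2-yl cap in this assay, as a 1.9-fold lower number from compound 3 to compound 4 (0.27 log units; within the scatter) shows, so neither ring of that group is needed to hold this level. The 4-fluorophenyl cap stays apart from tert-butyl, with a 5.1-fold higher number from compound 2 to compound 4 (0.71 log units; beyond the scatter) beyond the scatter, so compound 2 remains the one cap here that separates from the others. The amide bearing tert-butyl also cannot be told apart from the 2-hydroxy-3-phenylpropyl amine, as a 1.9-fold lower number from compound 1 to compound 4 (0.28 log units; within the scatter) lies within the scatter.

Nothing available explains these readings. Open, from the compounds shown here alone, is whether the reading of compound 2 depends on the fluorine or on the ring itself, which an unsubstituted phenyl or a cyclohexyl on the same carbonyl carbon would separate.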